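The source may hold more compounds than are shown below. What is called first, only, known or untested is meant among the compounds shown, and "the series" means these compounds.

In a functional assay on PC-3 cells (Homo sapiens) (a higher number here means a weaker inhibitor of growth, a lower number a stronger inhibitor of growth), so far:
- compound 1 `O=S(=O)(/C=C/c1ccc(Cl)c(Cl)c1)Cc1ccc(Nc2ncnc3ccccc23)cc1`: 35000 nM
- compound 2 `O=S(=O)(/C=C/c1ccc(Cl)c(Cl)c1)Cc1ccc(Nc2ncnc3ccc(Br)cc23)cc1`: 11000 nM

Compound 2 holds the lower of the two numbers at 11000 nM and is the reference here. Compound 3 `O=S(=O)(/C=C/c1ccc(F)cc1F)Cc1ccc(Nc2ncnc3ccc(Br)cc23)cc1` carries 2,4-difluorophenyl in place of 3,4-dichlorophenyl on a double-bonded chain carbon bound to a double-bonded chain carbon. Among the measured compounds shown here, the only measured step (a 3.2-fold lower number from compound 1 to compound 2 (0.50 log units; beyond the scatter)) is a modest one for bromo in place of hydrogen and does not involve this group. For the measured compounds named here, no measured step covers this exchange, so no direction can be drawn from the data, and a shift beyond the scatter is not expected. The estimated step is expected to be a 1.1-fold higher number from compound 2 to compound 3 (0.04 log units; within the scatter). Compound 3 is estimated at 12000 nM (expected range 4000 nM to 35000 nM).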

Compound 3, concentration for 50% growth inhibition: 100000 nM
Compound 3: middle estimate off by 8.3-fold (0.92 log units), on the low side; the measured number lies above the stated range.
By their numbers in this assay, from the lowest: compound 2; then compound 1; then compound 3.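

In this assay, the aryl group on the double-bonded chain carbon clearly matters: 2,4-difluorophenyl in place of 3,4-dichlorophenyl gives a 9.1-fold higher number from compound 2 to compound 3 (0.96 log units; beyond the scatter). Both groups have the same heavy-atom count and neither has hydrogen-bond donors or acceptors, so these counts do not separate them. Nothing available explains the step.

The halogen and its ring positions change together, so their separate contributions remain unresolved. Also open, as far as these compounds go, is how an amine or a carboxylic acid on this aryl group would compare.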